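This account rests on a few compounds, and the source may have more. Where it says the series, first, only, none or still open, it means among the compounds named here.

Measured in an ADME assay on MDCKII-LE cells (Canis lupus familiaris) for permeability, read by transwell migration, in the apical to basolateral direction; on this read-out lower numbers stand for lower permeability and higher numbers for higher permeability:
- Compound 1 `CC1(C)C[C@@H](CN([C@H](CCC(F)(F)F)C(N)=O)S(=O)(=O)c2ccc(Cl)cc2)O1`: 14.9 10^-6 cm/s
- Compound 2 `CC1(C)CO[C@H]1CN([C@H](CCC(F)(F)F)C(N)=O)S(=O)(=O)c1ccc(Cl)cc1`: 26.4 10^-6 cm/s
- Compound 3 `NC(=O)[C@@H](CCC(F)(F)F)N(C[C@@H]1CCCCO1)S(=O)(=O)c1ccc(Cl)cc1`: 15.4 10^-6 cm/s

All three compounds lie within the scatter of one another, so compound 3 cannot be separated from either neighbour. The measured steps to it are a 1.0-fold higher number from compound 1 to compound 3 (0.01 log units; within the scatter) and a 1.7-fold lower number from compound 2 to compound 3 (0.23 log units; within the scatter).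

The next compound, compound 4 `NC(=O)[C@@H](CCC(F)(F)F)N(C[C@@H]1CCOC1)S(=O)(=O)c1ccc(Cl)cc1`, differs from compound 3 by oxolan-3-yl in place of oxan-2-yl on a saturated chain carbon bound to a sulfonamide nitrogen. In words, it carries oxolan-3-yl in place of oxan-2-yl on a saturated chain carbon bound to a sulfonamide nitrogen.

Going by the values given here, no measured step makes this exact exchange. Among the compounds with values here, three steps bear on it, since each changes the group at the same place: the two above and a 1.8-fold higher number from compound 1 to compound 2 (0.25 log units; within the scatter). Each of them stayed within the scatter, even though the groups exchanged differ in their rings. On that evidence, a step beyond the scatter is not expected in this assay, and no direction can be firmly assigned.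

The expected step is a 1.0-fold lower number from compound 3 to compound 4 (0.01 log units; within the scatter), which would leave the number close to where it stands now. For compound 4 the estimated value is 15 10^-6 cm/s, with an expected range from 8 10^-6 cm/s to 27 10^-6 cm/s.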

Compound 4, apparent permeability: 20.5 10^-6 cm/s
Compound 4: middle estimate off by 1.4-fold (0.14 log units), on the low side; low and high end bracket the measured number.
By their numbers in this assay, from the lowest: compounds 1, 3, 4 and 2 (each within the scatter of the next).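

In this assay the exchange of the six-membered oxan-2-yl for the five-membered oxolan-3-yl gives a 1.3-fold higher number from compound 3 to compound 4 (0.12 log units; within the scatter) and so adds a further ring size and a different point of attachment at this place, on a saturated chain carbon bound to a sulfonamide nitrogen, without a step beyond the scatter. Compound 4 also stays unresolved from the two dimethyloxetane compounds, with a 1.3-fold lower number from compound 2 to compound 4 (0.11 log units; within the scatter) and a 1.4-fold higher number from compound 1 to compound 4 (0.14 log units; within the scatter) as the remaining steps, so the four groups shown form one band in which no order can be claimed. No independent measurement is available that would account for the small differences among these compounds.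

Going by these compounds, all four groups are saturated rings holding a single oxygen, so it remains open whether a piperidine ring, a carboxylic acid or an open methoxyethyl chain at the same place would also stay within the scatter. The compounds also leave open what the opposite configuration at the ring stereocentre of the oxolan-3-yl group would give on the same core.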